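The source may report more compounds than this note shows. Statements on the series, on what has been measured and on what is new or still open speak of the compounds shown alone.

Compound 3 `COc1ccc(N2C(=O)N(Cc3ccccc3F)c3ccccc3S2(=O)=O)cc1OC` carries a 2-fluorophenyl on a saturated chain carbon bound to an amide-type nitrogen in a ring. In an assay on isolated protein for displacement of a labelled ligand from Orexin/Hypocretin receptor type 1 (Homo sapiens), with a stated time of 90 min (on this read-out higher numbers stand for weaker inhibition and lower numbers for stronger inhibition), compound 3 gives 316 nM, the highest of the two plain numbers available; the nearest, compound 2 `COc1cc(F)c(CN2C(=O)N(c3ccc(OC)c(OC)c3)S(=O)(=O)c3ccccc32)c(F)c1`, gives 2 nM in this assay, so that a 160-fold higher number from compound 2 to compound 3 (2.20 log units; beyond the scatter). Compound 1 `COc1ccc(N2C(=O)N(Cc3ccc(F)cc3Cl)c3ccccc3S2(=O)=O)cc1OC` gives only a limit of this assay, > 2510 nM, not a number (the limit of > 2510 nM in this assay, at which 1 of the 3 values shown sits).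

Compound 4 `COc1ccc(N2C(=O)N(Cc3c(F)cc(F)cc3Cl)c3ccccc3S2(=O)=O)cc1OC` has not yet been measured. It differs from compound 3 in one place: 2-chloro-4,6-difluorophenyl in place of 2-fluorophenyl on a saturated chain carbon bound to an amide-type nitrogen in a ring. Among the measured compounds shown here, two measured steps bear on this. First, an at least 7.9-fold lower number from compound 1 to compound 3 (0.89 log units; beyond the scatter), and compound 4 brings a chlorine and a fluorine back in the same positions that compound 1 carries, with one extra fluorine. Second, an at least 1200-fold lower number from compound 1 to compound 2 (3.09 log units; beyond the scatter), where compound 2 carries fluorine on both sides of the chain carbon, a pattern compound 4 shares in part, though with chlorine on one side and without a methoxy. These pull in opposite directions, so a step is expected that is moderate at most and more likely toward a higher number than a lower one, with wide uncertainty. For compound 4 the estimate in this assay is 1000 nM, within a range of 100 nM to 6000 nM, an expected step of a 3.2-fold higher number from compound 3 to compound 4 (0.50 log units; beyond the scatter).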

Compound 4, inhibition constant: 25.1 nM
Beside the measured number, compound 4's estimate is 40-fold (1.60 log units) above it, outside the stated range (below it).
By their numbers in this assay, from the lowest: compound 2; then compound 4; then compound 3. At a limit, above all of these: compound 1.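

Within this position, a single fluoro in place of hydrogen on an aromatic carbon turns the 2-chloro-4-fluorophenyl into the 2-chloro-4,6-difluorophenyl, and in this assay this gives an at least 100-fold lower number from compound 1 to compound 4 (2.00 log units; beyond the scatter) as a minimum size, since compound 1 stands at a limit and not at a number: the limit of > 2510 nM in this assay, at which 1 of the 4 values shown sits. The chlorine-bearing group therefore need not be the poorer choice, as the comparison with the plain 2-fluorophenyl gives a 13-fold lower number from compound 3 to compound 4 (1.10 log units; beyond the scatter) and reverses the order that compound 1 and compound 3 showed on their own. Even so, the 2,6-difluoro-4-methoxyphenyl stays ahead, with a 13-fold higher number from compound 2 to compound 4 (1.10 log units; beyond the scatter) as the remaining gap, so compound 2 keeps the lowest number of the four.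

The steps show how far the numbers move on this aromatic ring, but nothing measured among these compounds says why a single added fluoro moves them so far. Also open, from the compounds shown here alone, is how the position would respond to an amine or a nitrile on that ring, or to a longer chain in place of the saturated chain carbon.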